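Swapping a long chain for cyclohexyl

A few compounds are considered here, and "the series" means these few. Any claim that something is new, unique, unknown or untested is made for them only; others in the source may bear on it.

Compound 1 `CCCCCCOc1cccc(O)c1C(=O)/C=C/c1ccc(O)cc1`: > 30000 nM, a limit
Compound 2 `CCCCC/C=C\CCCCOc1cccc(O)c1C(=O)/C=C/c1ccc(O)cc1`: > 30000 nM, a limit

In an ADME assay on RAW264.7 cells (Mus musculus) for cytotoxicity, read by MTT assay (a higher number here means a weaker inhibitor, a lower number a stronger inhibitor), compound 2 gives > 30000 nM, which is a limit and not a number. Compound 1 likewise gives only a limit, > 30000 nM. The record so far is therefore (the limit of > 30000 nM in this assay, at which 2 of the 2 values shown sit), and no exact value has been measured for either compound.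

Compound 3 `O=C(/C=C/c1ccc(O)cc1)c1c(O)cccc1OCC1CCCCC1` keeps the shared core and differs from compound 2 in one place: cyclohexyl in place of dec-4-en-1-yl on a saturated chain carbon bound to an oxygen on an aromatic ring. Its ring-bearing group is smaller than the dec-4-en-1-yl chain it replaces.

Among the measured compounds shown here, only one measured step bears on this change, as it also alters the chain: a step that the two limits leave unreadable from compound 1 to compound 2. That step offers no size to carry over, so no step beyond the scatter and no direction can be expected in this assay. The expected step is a step that the limit leaves unreadable from compound 2 to compound 3. Compound 3 is estimated at 35000 nM, with an expected range of 15000 nM to 80000 nM, and it may well be reported only as a limit.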

Compound 3, half-maximal inhibitory concentration: > 30000 nM
Compound 3 ended at the assay's limit; the forecaster's own chance of this, stated with the estimate: 80%; the middle value lies beyond the limit too.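

In this assay compound 3 gives > 30000 nM, which is a limit and not a number. Among the compounds shown here, with compound 1 and compound 2 also given only as limits, no step among the three compounds can be read. The compounds shown leave open what exact value each one has in this assay, and whether exchanging dec-4-en-1-yl for cyclohexyl changes it at all.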